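A few compounds are considered here, and "the series" means these few. Any claim that something is new, unique, unknown or untested is made for them only; others in the source may bear on it.

Measured in a physicochemical assay, with a stated time of 6 min; on this read-out higher numbers stand for weaker inhibition and lower numbers for stronger inhibition:
- Compound 1 `COc1ccc(NC(=O)Nc2nc(-c3cc4cc([N+](=O)[O-])ccc4o3)cs2)cc1`: 121000 nM
- Compound 2 `COc1ccc(NC(=O)Nc2nc(-c3cc4ccccc4o3)cs2)cc1`: 17400 nM
- Compound 3 `COc1ccc(NC(=O)Nc2nc(-c3cc4cc(Br)ccc4o3)cs2)cc1`: > 200000 nM (a limit of the assay, not a number)

Only compound 1 and compound 2 have true numbers, and compound 2 holds the lower one at 17400 nM. Its nearest neighbour is compound 1, with a 7.0-fold lower number from compound 1 to compound 2 (0.84 log units; beyond the scatter). Compound 3 is reported only as a limit, > 200000 nM.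

The next molecule, compound 4 `O=C(Nc1cccc(F)c1)Nc1nc(-c2cc3ccccc3o2)cs1`, is made from compound 2 by one change: 3-fluorophenyl in place of 4-methoxyphenyl on an amide-type nitrogen. In words, 3-fluorophenyl stands in place of 4-methoxyphenyl on an amide-type nitrogen.

Within the data shown here, no measured step touches that group. All of them exchange hydrogen, nitro or bromo on an aromatic carbon, so they give no direction for this change. They show only how far a single exchange can move the number in this series: a 7.0-fold lower number from compound 1 to compound 2 (0.84 log units; beyond the scatter), and an at least 11-fold higher number from compound 2 to compound 3 (1.06 log units; beyond the scatter), the latter a floor set by a limit.

With no direction to go on in this assay, no shift beyond the scatter is expected, and the expected step is a 1.1-fold higher number from compound 2 to compound 4 (0.06 log units; within the scatter). The range stays wide, given the size of an at least 11-fold higher number from compound 2 to compound 3 (1.06 log units; beyond the scatter).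

For compound 4 the estimated value is 20000 nM, with an expected range from 6000 nM to 70000 nM.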

Compound 4, half-maximal inhibitory concentration: 4520 nM
Compound 4: middle estimate off by 4.4-fold (0.65 log units), on the high side, and the stated range ends above it.
By their numbers in this assay, from the lowest: compound 4; then compound 2; then compound 1. At a limit, above all of these: compound 3.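

In this assay the group on the amide-type nitrogen proves able to move the number, since 3-fluorophenyl in place of 4-methoxyphenyl gives a 3.8-fold lower number from compound 2 to compound 4 (0.59 log units; beyond the scatter) and so stronger inhibition. Among these compounds, all the earlier steps exchanged hydrogen, nitro or bromo on an aromatic carbon, so this is the first measured sign that this second site also responds to change, and that at least one replacement there is tolerated and even helpful. The change alters both the atom carried on the six-membered ring and where the group's name places it, and nothing measured here explains why the number fell.

The compounds shown leave open whether the gain comes from the fluorine itself, from losing the methoxy group, or from the different placing on the ring, a question that a plain phenyl group on the same nitrogen would help to answer. They also leave open how far this site can be pushed with quite different groups, such as an amine or a carboxylic acid on that phenyl ring, and whether the gain would carry over to the nitro and bromo versions of the core.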